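This account rests on a few compounds, and the source may have more. Where it says the series, first, only, none or still open, it means among the compounds named here.

Measured compounds in a functional assay on SGC-7901 cells (Homo sapiens) for antiproliferative activity, read by MTT assay, with a stated time of 72 h; a higher number here means a weaker inhibitor, a lower number a stronger inhibitor:
compound 1 `COc1cc(-n2cnc3ccc(-c4ccc(C(C)=O)cc4)cc32)cc(OC)c1OC` gives 450 nM
compound 2 `COc1cc(-n2cnc3ccc(-c4cccc(O)c4)cc32)cc(OC)c1OC` gives 53 nM

Compound 2 holds the lowest number of the two in this assay; its nearest neighbour is compound 1, separated by an 8.5-fold lower number from compound 1 to compound 2 (0.93 log units; beyond the scatter). Compound 3 `COc1ccc(-c2ccc3ncn(-c4cc(OC)c(OC)c(OC)c4)c3c2)cc1` has not yet been measured. The change from compound 2 to compound 3 is 4-methoxyphenyl in place of 3-hydroxyphenyl on an aromatic carbon. Going by the values given here, only one measured step exists, from compound 1 to compound 2, and it swaps a different pair of groups at the same place, so it bears on the new step only loosely: it shows that the group at this position can move the number by a modest amount. Among the compounds with values here, no measured pair speaks to replacing 3-hydroxyphenyl with 4-methoxyphenyl. Compound 3 is therefore expected to lie near compound 2, the estimated step being a 1.9-fold higher number from compound 2 to compound 3 (0.28 log units; within the scatter), with a wide range. The estimate for compound 3 in this assay is 100 nM, between 30 nM and 400 nM.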

Compound 3, half-maximal inhibitory concentration: 82 nM
For compound 3 the middle estimate is 1.2-fold (0.09 log units) above the measured one; the measured number falls inside the stated range.
By their numbers in this assay, from the lowest: compounds 2 and 3 (each within the scatter of the next); then compound 1.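

In this assay, the change gives a 1.5-fold higher number from compound 2 to compound 3 (0.19 log units; within the scatter) and so shows that, among these compounds, a low number at this position does not depend on a hydrogen-bond donor: 3-hydroxyphenyl has 1 and 4-methoxyphenyl has 0. Methoxy in place of acetyl on the phenyl ring gives a 5.5-fold lower number from compound 1 to compound 3 (0.74 log units; beyond the scatter) and shows that the number responds to the group at that same ring place, not only to which aryl group is attached to the core. Nothing given here explains either step.

The step from 3-hydroxyphenyl to 4-methoxyphenyl changes both the group and its place on the phenyl ring, and the compounds shown cannot separate these two changes. As far as these compounds go, it also remains open how 3-methoxyphenyl, or an amine or a carboxylic acid on this phenyl ring, would read.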